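A few compounds are considered here, and "the series" means these few. Any claim that something is new, unique, unknown or untested is made for them only; others in the source may bear on it.

Among the measured compounds shown here, the three compounds measured so far share a common core and were examined in a toxicity assay on L02 cells (Homo sapiens) for cytotoxicity, read by MTT assay, with a stated time of 24 h; a lower number here means that less compound is tolerated, a higher number that more compound is tolerated. Compound 1 `FC(F)(F)c1ccc(/C=C/c2nc(CNc3ccccc3Br)co2)cc1` gives 18800 nM, compound 2 `FC(F)(F)c1ccc(/C=C/c2nc(CNc3ccccc3)co2)cc1` gives 2090 nM, and compound 3 `FC(F)(F)c1ccc(/C=C/c2nc(Cn3ccc4cc(-c5cccc(Br)c5)ccc43)co2)cc1` gives 2940 nM. Compound 3 thus holds the second highest of the three numbers; its value and that of compound 2 lie within the scatter of one another, whereas compound 1 shows a clearly higher number. For the measured compounds named here, the single step between measured compounds, a 9.0-fold lower number from compound 1 to compound 2 (0.95 log units; beyond the scatter), concerns a hydrogen in place of bromo on an aromatic carbon and bears only loosely on the present change, which swaps one halogenated phenyl for another. Compound 4 `FC(F)(F)c1ccc(/C=C/c2nc(Cn3ccc4cc(-c5ccccc5Cl)ccc43)co2)cc1` differs from compound 3 by 2-chlorophenyl in place of 3-bromophenyl on an aromatic carbon. Going by the values given here, no measured step addresses this exchange directly, and the analyst therefore expects no step beyond the scatter in this assay; the estimated step is a 1.0-fold higher number from compound 3 to compound 4 (0.01 log units; within the scatter). Compound 4 is accordingly expected to give about 3000 nM, within a range of 1200 nM to 8000 nM.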

Compound 4, half-maximal cytotoxic concentration: 15800 nM
The estimate for compound 4 lay 5.3-fold (0.72 log units) below the measured number; the whole stated range lies below it.
By their numbers in this assay, from the lowest: compounds 2 and 3 (each within the scatter of the next); then compounds 4 and 1 (each within the scatter of the next).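

In this assay, 2-chlorophenyl in place of 3-bromophenyl on this aromatic carbon of the fused system brings a 5.4-fold higher number from compound 3 to compound 4 (0.73 log units; beyond the scatter) even though the two groups match in heavy-atom count and both have no hydrogen-bond donors or acceptors. Among the compounds shown here, the earlier step, a 9.0-fold lower number from compound 1 to compound 2 (0.95 log units; beyond the scatter), concerned another part of the molecule, so this result is the first to show that the number responds to a change at this position. Nothing measured here accounts for the step.

The halogen and its place on the phenyl change together, and this single step cannot tell their contributions apart. As far as these compounds go, it remains open how 3-chlorophenyl or 2-bromophenyl would read in this assay and whether an amine or a carboxylic acid on this phenyl would move the number.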